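The compounds below may be only part of what the source reports. "The series", "measured", "known", "first", "only" and "open" are said of these compounds alone.

Compound 3 `C[C@H](CF)OC(=O)N1CCC(O[C@H]2CC[C@H](Oc3cnc(S(C)(=O)=O)cn3)CC2)CC1` carries a 1-(fluoromethyl)ethyl group on an oxygen next to the carbonyl of the shared core. In a functional assay on isolated protein for agonist activity at Glucose-dependent insulinotropic receptor (Homo sapiens), read by HTRF and cAMP accumulation (a lower number here means that less compound is needed, a higher number that more compound is needed for the effect), compound 3 gives 36.8 nM, the higher of the two numbers shown. Among the compounds with values here, compound 2 `CC(C)(C)OC(=O)N1CCC(O[C@H]2CC[C@H](Oc3cnc(S(C)(=O)=O)cn3)CC2)CC1` is its tert-butyl counterpart; in this assay compound 2 gives 5.9 nM, and the step of a 6.2-fold higher number from compound 2 to compound 3 (0.79 log units; beyond the scatter) is the only measured step available. Compound 1 `CC(C)(C)OC(=O)N1CCC(OC2CCCC(Oc3ccc(S(C)(=O)=O)cc3)C2)CC1` reaches only the assay limit (the limit of > 100000 nM in this assay, at which 1 of the 3 values shown sits), so its result of > 100000 nM is a limit and not a number. Compound 4 `CS(=O)(=O)c1cnc(O[C@H]2CC[C@H](OC3CCN(C(=O)C4(C(F)(F)F)CC4)CC3)CC2)cn1` differs from compound 3 by a group of 7 heavy atoms (4 carbon, 3 fluorine; one three-membered non-aromatic ring of carbon only) in place of a group of 5 heavy atoms (3 carbon, 1 oxygen, 1 fluorine; no ring), on a carbonyl carbon. No measured step covers this exchange; the single step shown concerns the other side of the carbonyl and is modest. The step of a 1.8-fold lower number from compound 3 to compound 4 (0.26 log units; within the scatter) is therefore expected to stay small. Compound 4 is estimated at 20 nM, within a range from 4 nM to 100 nM.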

Compound 4, half-maximal effective concentration: 107 nM
Estimate against measurement, compound 4: 5.4-fold (0.73 log units) below, and the stated range ends below it.
By their numbers in this assay, from the lowest: compound 2; then compound 3; then compound 4. At a limit, above all of these: compound 1.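

With 1-(trifluoromethyl)cyclopropyl on the carbonyl carbon, the number rises in this assay, with a 2.9-fold higher number from compound 3 to compound 4 (0.46 log units; beyond the scatter) and an 18-fold higher number from compound 2 to compound 4 (1.26 log units; beyond the scatter). This shows that the carbonyl carbon's substituent matters here: the tert-butoxy group of compound 2 gives way to a carbon-linked group at a clear cost, and the change is large. Nothing shown gives a reason for this rise. On these data alone, it remains open whether the rise follows from the cyclopropyl ring, the trifluoromethyl group or the change from oxygen to carbon at that attachment. As far as these compounds go, what an amine on the same carbonyl carbon would give also remains open.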